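Swapping the lactam aryl group on an inactive analogue

The source may report more compounds than this note shows. Statements on the series, on what has been measured and on what is new or still open speak of the compounds shown alone.

Measured compounds:
compound 1, `O=C1CC(c2nc(-c3ccccc3)no2)CN1c1ccccc1`, 350 nM
compound 2, `O=C1CC(c2nc(-c3cccc(Cl)c3)no2)CN1c1cccc(Cl)c1`, > 10000 nM
compound 3, `COc1cccc(-c2noc(C3CC(=O)N(c4ccc(F)cc4)C3)n2)c1`, 1100 nM

In an in vitro functional assay on HEK293-A cells for positive allosteric modulation of metabotropic glutamate receptor 5 (Homo sapiens), read by FLIPR and calcium flux (a lower number here means that less compound is needed, a higher number that more compound is needed for the effect), compound 1 gives 350 nM and compound 3 gives 1100 nM. For compound 2 the result is only a limit, > 10000 nM, so its true value is not known. Of the three results, one reaches this limit (the limit of > 10000 nM in this assay, at which 1 of the 3 values shown sits). Compound 4, `Cc1ccc(N2CC(c3nc(-c4cccc(Cl)c4)no3)CC2=O)cc1C`, keeps the rest of compound 2 and changes one group: 3,4-dimethylphenyl in place of 3-chlorophenyl on an amide-type nitrogen in a ring. Going by the values given here, no step of this kind has been measured here, so the direction is open. A modest gain is expected rather than none, but compound 4 is estimated at 6000 nM, within 1500 nM to 30000 nM, so that the expected step of an at least 1.6-fold lower number from compound 2 to compound 4 (0.22 log units; that floor lies within the scatter) may still leave the result at a limit.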

Compound 4, half-maximal effective concentration: 310 nM
Estimate against measurement, compound 4: 19-fold (1.29 log units) above, outside the stated range (below it).
By their numbers in this assay, from the lowest: compounds 4 and 1 (each within the scatter of the next); then compound 3. At a limit, above all of these: compound 2.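

In this assay, the group on the amide-type nitrogen in a ring proves decisive: with the rest of the molecule unchanged, 3,4-dimethylphenyl in place of 3-chlorophenyl gives an at least 32-fold lower number from compound 2 to compound 4 (1.50 log units; beyond the scatter). This single swap is enough to bring a compound up from the assay limit to a measurable value. The result for compound 2 is a limit, not a number: the limit of > 10000 nM in this assay, at which 1 of the 4 values shown sits.

The compounds shown leave open how a single methyl group on this phenyl ring, or a methoxy group or an amine, would behave here. From the compounds shown here alone, whether the same swap gives a similar gain when the rest of the molecule differs also remains open.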